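The source may hold more compounds than are shown below. What is called first, only, known or untested is meant among the compounds shown, and "the series" means these compounds.

Measured compounds:
compound 1, `O=C(/C=C/c1cn([C@@H]2C[C@H](CO)N(CCCc3ccccc3)C2)nn1)NO`: 12%
compound 2, `O=C(NO)c1ccc(-c2cn([C@@H]3C[C@H](C(=O)O)N(CCCc4ccccc4)C3)nn2)cc1`: < 10%
compound 3, `O=C(/C=C/c1cn([C@@H]2C[C@@H](C(=O)O)N(CCCc3ccccc3)C2)nn1)NO`: < 10%

Of the compounds shown here, three have been tested in an assay on Sf9 cells for inhibition of histone deacetylase 11 (Homo sapiens), read by fluorescence, tested at 0.5 uM; on this read-out higher numbers stand for more inhibition at the one concentration tested (going by the name of the read-out) and lower numbers for less inhibition. Compound 1 gives 12% in this assay. For compound 2 this assay reports only a limit, < 10%, and not a number. For compound 3 this assay likewise reports only a limit, < 10%. Compound 3 therefore stands at the floor of what this assay resolves, and it shares that position with compound 2, since (the limit of < 10% in this assay, at which 2 of the 3 values shown sit). Compound 1 sits a little higher, but its gap to the two limits is within the usual scatter of such readings, so no order among the three can be drawn.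

Compound 4, `O=C(/C=C/c1cn([C@@H]2C[C@H](C(=O)O)N(CCCc3ccccc3)C2)nn1)NO`, has not yet been measured in this assay. Compared with compound 3, (the two compounds have the same atoms and bonds and differ only in configuration as drawn: 1 of 3 stereo elements differ; a stereocentre at a saturated ring carbon is drawn S in compound 3 and R in compound 4). No measured pair in this set differs in one place, so no measured step guides the expectation; the change is a single inversion of configuration at a saturated ring carbon, and on the numbers shown the expected step in this assay from compound 3 to compound 4 is none beyond the scatter, a number no lower from compound 3 to compound 4 (the limit leaves the size open). Compound 4 is estimated to give 10% in this assay, within 3% to 20%.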

Compound 4, a percentage reported as inhibition, at one concentration (the size of the read-out at that concentration, not a potency): 11%
Compound 4: middle estimate off by 1 percentage points, on the low side, and the stated range covers the measured number.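

In this assay, going by these compounds alone, compound 4 supplies the first number for a carboxy compound in this set, so the inversion at the saturated ring carbon now has a measured value on one side, and the step reads a number at least 1 percentage points higher from compound 3 to compound 4 (that floor lies within the scatter), which does not establish any effect of configuration, since the comparison isolates that one feature alone: the fact that compounds 3 and 4 differ only in the configuration as drawn. Within the data shown here, the exchange of hydroxymethyl for carboxy on a saturated ring carbon is the first change here with numbers at both ends, and it reads a number 1 percentage points lower from compound 1 to compound 4 (within the scatter), so this change shows nothing beyond the scatter at the one concentration tested. From the compounds shown here alone, the exchange of 4-(hydroxycarbamoyl)phenyl for 2-(hydroxycarbamoyl)ethenyl reads a number at least 1 percentage points higher from compound 2 to compound 4 (that floor lies within the scatter), and its true size stays unknown, as one end of the step is only a limit: the limit of < 10% in this assay, at which 2 of the 4 values shown sit.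

All the readings in this assay remain near the bottom of what it resolves, which leaves open whether any part of these structures can raise the inhibition at all. Going by these compounds, whether an amine or a primary amide on that saturated ring carbon would read differently from carboxy or hydroxymethyl also remains open.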